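A few compounds are considered here, and "the series" means these few. Any claim that something is new, unique, unknown or untested is made for them only; others in the source may bear on it.

Working notes on the series.

Compound 1 `COc1ccccc1OCC1SCCN1C(=O)CN` is the reference point here. Among the compounds with values here, in a functional assay on the whole organism for inhibition, with Cavia porcellus as the target (on this read-out lower numbers stand for an effect already at smaller amounts and higher numbers for an effect only at larger amounts of compound), compound 1 gives 57 mg/kg, which is the highest of the two numbers so far. Within the data shown here, the only other measured member, compound 2 `CCOC(=O)CC(=O)N1CCS(=O)(=O)C1COc1ccccc1OC`, shows a lower number in this assay: compound 2 gives 28 mg/kg, a gap to compound 1 that lies beyond the usual scatter of repeated measurements. Compound 2 differs from compound 1 in more than one place, so nothing can be read from that pair about any single change.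

Compound 3 `COc1ccccc1OCC1SCCN1C(=O)CC(=O)N1CCN(C)CC1` has not yet been measured. The change from compound 1 is (4-methylpiperazin-1-yl)carbonyl in place of amino on a saturated chain carbon bound to a carbonyl carbon. Among the measured compounds shown here, no step between measured compounds covers this change, so the expectation rests on compound 1 alone: a moderate shift toward a lower number is expected, a 1.6-fold lower number from compound 1 to compound 3 (0.21 log units; within the scatter), and it may not clear the scatter. Compound 3 is therefore estimated at 35 mg/kg in this assay, with a range from 12 mg/kg to 100 mg/kg.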

Compound 3, dose for half-maximal effect: 27 mg/kg
Estimate against measurement, compound 3: 1.3-fold (0.11 log units) above; measured number inside the range.
By their numbers in this assay, from the lowest: compounds 3 and 2 (each within the scatter of the next); then compound 1.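

The amino group is not needed for activity at this position, on a saturated chain carbon bound to a carbonyl carbon. In this assay, within the data shown here, (4-methylpiperazin-1-yl)carbonyl, a much larger group with no hydrogen-bond donor, takes its place with a 2.1-fold lower number from compound 1 to compound 3 (0.32 log units; beyond the scatter), the only change in a single place that can be read so far. No measurement shown explains this step.

As far as these compounds go, it remains open which part of the entering group carries the step, as a dimethylamino group, a morpholin-4-ylcarbonyl group or a piperazin-1-ylcarbonyl group without the methyl would test different parts of it at the same place. From the compounds shown here alone, it also remains open whether the same exchange would give a similar step on the core of compound 2.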